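The source may hold more compounds than are shown below. What is called first, only, known or untested is meant among the compounds shown, and "the series" means these compounds.

In an ADME assay on MT4 cells (Homo sapiens) for cytotoxicity, read by MTT assay, with a stated time of 5 days (a higher number here means that more compound is tolerated, a lower number that less compound is tolerated), the measured compounds are

Compound 1 (`CCOC(=O)Cn1cc(CNC(=O)c2cnc(Nc3ccc(C#N)cc3)cc2Oc2c(C)cc(C)cc2C)nn1`) with 9530 nM
Compound 2 (`Cc1cc(C)c(Oc2cc(Nc3ccc(C#N)cc3)ncc2C(=O)NCc2cn(CC(N)=O)nn2)c(C)c1`) with 24000 nM

Compound 2 gives the higher of these two numbers, and compound 1 is its nearest neighbour. Compound 3 (`Cc1cc(C)c(Oc2cc(Nc3ccc(C#N)cc3)ncc2C(=O)NCc2cn(CCC#N)nn2)c(C)c1`) has not yet been measured. It carries cyanomethyl in place of carbamoyl on a saturated chain carbon bound to an aromatic nitrogen and keeps the rest of compound 2 unchanged. Among the compounds with values here, only one measured step bears on this change, the modest 2.5-fold higher number from compound 1 to compound 2 (0.40 log units; beyond the scatter) with amino in place of ethoxy on a carbonyl carbon. Compound 3 no longer has the carbamoyl, so a modest move to a lower number is expected in this assay, of that size or smaller. The estimate amounts to a 1.7-fold lower number from compound 2 to compound 3 (0.23 log units; within the scatter) as the expected step. For compound 3 the estimated value is 14000 nM with an expected range from 6000 nM to 30000 nM in this read-out.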

Compound 3, half-maximal cytotoxic concentration: 40200 nM
Compound 3: the middle estimate sits 2.9-fold (0.46 log units) below what was measured, outside the stated range (above it).
By their numbers in this assay, from the lowest: compound 1; then compounds 2 and 3 (each within the scatter of the next).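

In this assay, cyanomethyl in place of carbamoyl on a saturated chain carbon bound to an aromatic nitrogen gives a 1.7-fold higher number from compound 2 to compound 3 (0.22 log units; within the scatter) and so does not separate the two groups, even though the hydrogen-bond donor of carbamoyl is gone. Cyanomethyl in place of ethoxycarbonyl at the same place gives a 4.2-fold higher number from compound 1 to compound 3 (0.63 log units; beyond the scatter) in this read-out, so compound 1, with its ethoxycarbonyl, now stands apart from both compound 2 and compound 3 by steps beyond the scatter. Nothing available here accounts for these numbers.

The compounds shown leave open whether a carboxylic acid or an amine at this place would give a number apart from those of compound 2 and compound 3. They also leave open whether a longer chain ending in a nitrile would do so.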